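Furan to thiophene on the saturated ring carbon

The compounds below may be only part of what the source reports. "The series", "measured", "known", "first", "only" and "open" are said of these compounds alone.

Compound 2 `CC1=C(C(=O)OC(C)C)C(c2ccco2)N/C(=N/C#N)N1` gives 21% in an assay on cells for displacement of a labelled ligand from adenosine receptor A1 (Homo sapiens), with a stated time of 60 min, tested at 1 uM; on this read-out higher numbers stand for more inhibition at the one concentration tested (going by the name of the read-out) and lower numbers for less inhibition. Within the data shown here, compound 1 `CC1=C(C(=O)OC(C)C)C(c2ccccc2)N/C(=N/C#N)N1` gives 20% in this assay, and the step of a number 1 percentage points higher from compound 1 to compound 2 (within the scatter) shows that the two numbers cannot be told apart; compound 2 thus stands level with the only other measured compound of the series.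

Compound 3 `CC1=C(C(=O)OC(C)C)C(c2cccs2)N/C(=N/C#N)N1` carries the change (thiophen-2-yl in place of furan-2-yl on a saturated ring carbon). Among the measured compounds shown here, the one measured step that touches this position, a number 1 percentage points higher from compound 1 to compound 2 (within the scatter), exchanged one aromatic ring for another at the same saturated ring carbon without any shift beyond the scatter. For the measured compounds named here, no other step bears on the change. The expectation is therefore a step of a number 1 percentage points higher from compound 2 to compound 3 (within the scatter) that stays within the scatter. Compound 3 is accordingly estimated at 22% in this assay, with a range from 8% to 38%.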

Compound 3, a percentage reported as inhibition, at one concentration (the size of the read-out at that concentration, not a potency): 31%
Compound 3: the middle estimate sits 9 percentage points below what was measured; measured number inside the range.
By their numbers in this assay, from the lowest: compounds 1, 2 and 3 (each within the scatter of the next, the first and the last beyond it).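

In this assay, among these compounds, the thiophen-2-yl group gives the first step beyond the scatter at this saturated ring carbon (a number 11 percentage points higher from compound 1 to compound 3 (beyond the scatter)), though the step from the furan-2-yl group stays within it (a number 10 percentage points higher from compound 2 to compound 3 (within the scatter)). The position is therefore not wholly indifferent to the aromatic ring it carries, but only the phenyl and thiophen-2-yl groups can be told apart, and the furan-2-yl group cannot be separated from either. No supporting measurement on hand accounts for this modest step.

Still open, from the compounds shown here alone, is whether the response extends to a thiophen-3-yl group, a pyridin-3-yl ring or a non-aromatic cyclohexyl group on the same carbon. The compounds shown also leave open whether an ethoxycarbonyl group in place of the isopropoxycarbonyl group would alter the picture.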